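The source may report more compounds than this note shows. Statements on the series, on what has been measured and on what is new or still open speak of the compounds shown alone.

Compound 1 `C=CCn1nc(-c2cccnc2)c2ccccc2c1=O` is the starting point. In a functional assay (trachea) with Cavia porcellus as the target (on this read-out higher numbers stand for weaker inhibition and lower numbers for stronger inhibition), compound 1 gives 2140 nM. Its two companions differ from it only at the saturated chain carbon bound to an aromatic nitrogen: compound 2 `O=c1c2ccccc2c(-c2cccnc2)nn1Cc1ccccc1` gives 2450 nM in this assay, and compound 3 `O=c1c2ccccc2c(-c2cccnc2)nn1Cc1cccc(Cl)c1` gives 4170 nM. Compound 1 stands at one end of the three numbers, but the spread is small: a 1.1-fold higher number from compound 1 to compound 2 (0.06 log units; within the scatter), a 1.9-fold higher number from compound 1 to compound 3 (0.29 log units; within the scatter), and a 1.7-fold higher number from compound 2 to compound 3 (0.23 log units; within the scatter), so none of the three can be told apart.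

Compound 4 `CCOC(=O)Cn1nc(-c2cccnc2)c2ccccc2c1=O` makes a change at the same place: ethoxycarbonyl in place of vinyl on a saturated chain carbon bound to an aromatic nitrogen. Going by the values given here, the steps that bear on it are the two swaps at this position that have already been measured, from vinyl to phenyl and from vinyl to 3-chlorophenyl; both stayed within the scatter. Ethoxycarbonyl is a different kind of group from either aryl, so its step cannot be read off directly, yet nothing measured here points to a shift beyond the scatter in either direction. Compound 4 is therefore expected to land at about 2800 nM, within 1100 nM to 7000 nM, which is an expected step of a 1.3-fold higher number from compound 1 to compound 4 (0.12 log units; within the scatter).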

Compound 4, half-maximal inhibitory concentration: 43700 nM
The estimate for compound 4 lay 16-fold (1.19 log units) below the measured number, and the stated range ends below it.
By their numbers in this assay, from the lowest: compounds 1, 2 and 3 (each within the scatter of the next); then compound 4.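

In this assay there is a 20-fold higher number from compound 1 to compound 4 (1.31 log units; beyond the scatter) and an 18-fold higher number from compound 2 to compound 4 (1.25 log units; beyond the scatter) and also a 10-fold higher number from compound 3 to compound 4 (1.02 log units; beyond the scatter) at this one position, which makes compound 4 the weakest inhibitor of the four. The saturated chain carbon bound to an aromatic nitrogen therefore does respond to what it carries, something the swaps among vinyl, phenyl and 3-chlorophenyl could not show, since those all stayed within the scatter. No measurement available here explains why ethoxycarbonyl stands so far apart from the other three groups.

Going by these compounds alone, with only one such group, it remains open which part of ethoxycarbonyl goes with the weaker inhibition. A carboxylic acid, an amide or a plain longer carbon chain at the same place could help separate the carbonyl from the ethyl end.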